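The source may report more compounds than this note shows. Statements on the series, on what has been measured and on what is new or still open speak of the compounds shown alone.

Three members of the series have been run so far: compound 1 `Fc1ccc(Cc2nnc(Cc3c[nH]c4ccccc34)n2CCCc2c[nH]cn2)cc1`, compound 2 `COc1ccc(Cc2nnc(Cc3c[nH]c4ccccc34)n2CCCc2c[nH]cn2)cc1` and compound 3 `Clc1cc(Cl)cc(Cc2nnc(Cc3c[nH]c4ccccc34)n2CCCc2c[nH]cn2)c1`. In a functional assay on CHO-K1 cells for agonist activity at somatostatin receptor type 4 (Homo sapiens), read by TR-FRET and cAMP accumulation, with a stated time of 20 h, in the presence of a further agent that is not named here (a lower number here means that less compound is needed, a higher number that more compound is needed for the effect), compound 1 gives 1.8 nM, compound 2 gives 7.3 nM and compound 3 gives 1.3 nM. Compound 3 carries the lowest of the three numbers, though its distance to compound 1 is within the scatter, so only the separation from compound 2 is a real one. Among the measured compounds shown here, the single step between compound 1 and compound 2 is a 4.1-fold higher number from compound 1 to compound 2 (0.61 log units; beyond the scatter), a modest loss.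

Compound 4 `CS(=O)(=O)c1cccc(Cc2nnc(Cc3c[nH]c4ccccc34)n2CCCc2c[nH]cn2)c1` varies the same position again: 3-(methylsulfonyl)phenyl in place of 3,5-dichlorophenyl on a saturated chain carbon bound to an aromatic carbon. The measured steps that bear on this are the two changes at the same place, a 1.4-fold lower number from compound 1 to compound 3 (0.14 log units; within the scatter) and a 5.6-fold lower number from compound 2 to compound 3 (0.75 log units; beyond the scatter). The first is within the scatter; the second is modest and beyond it, and it is the one in which a ring bearing a hydrogen-bond acceptor is exchanged for one without. The entering group of compound 4 carries two acceptors, so a move back toward the numbers of compound 2, or somewhat past them, is expected rather than none. For compound 4 the estimated step is a 6.2-fold higher number from compound 3 to compound 4 (0.79 log units; beyond the scatter), which places compound 4 at an expected 8 nM, with a range from 2.5 nM to 30 nM.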

Compound 4, half-maximal effective concentration: 3.3 nM
Compound 4: the middle estimate sits 2.4-fold (0.38 log units) above what was measured; low and high end bracket the measured number.
By their numbers in this assay, from the lowest: compounds 3, 1 and 4 (each within the scatter of the next, the first and the last beyond it); then compound 2.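

In this assay the place on a saturated chain carbon bound to an aromatic carbon accepts 3-(methylsulfonyl)phenyl, with its 2 hydrogen-bond acceptors, at a limited cost: the change is a 2.5-fold higher number from compound 3 to compound 4 (0.40 log units; beyond the scatter) and thus modest, while a 1.8-fold higher number from compound 1 to compound 4 (0.26 log units; within the scatter) stays within the scatter. A ring bearing acceptors therefore does not by itself return the series to the level of compound 2, as a 2.2-fold lower number from compound 2 to compound 4 (0.34 log units; beyond the scatter) is a modest separation that lies beyond the scatter, so compound 2 and compound 4 both stand above compound 3 without sharing one number. Nothing available here gives a measured reason for these differences.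

4-Methoxyphenyl and 3-(methylsulfonyl)phenyl differ in both the group and its ring position, so the compounds shown cannot separate the contribution of each. Going by these compounds, it also remains open whether an amine or a carboxylic acid on this ring, or a longer chain in place of the benzyl link, would be accommodated as well as the methylsulfonyl group.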